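Solubility notes: rearranging the amino azetidine group

This account rests on a few compounds, and the source may have more. Where it says the series, first, only, none or still open, it means among the compounds named here.

For the measured compounds named here, in a physicochemical assay for solubility, at pH 7.4 (a lower number here means a less soluble compound, a higher number a more soluble compound), compound 1 `C[C@H]1[C@H](N)CN1c1nc2c(cc1F)c(=O)c(C(=O)O)cn2C1CC1` gives 20.3 ug/mL, the higher of the two numbers so far. Compound 2 `CNC1(C)CN(c2cc3c(cc2F)c(=O)c(C(=O)O)cn3C2CC2)C1` gives 0.7 ug/mL, a gap beyond the usual scatter. Compound 3 `CC1(N)CN(c2nc3c(cc2F)c(=O)c(C(=O)O)cn3C2CC2)C1` carries 3-amino-3-methylazetidin-1-yl on the aromatic carbon where compound 1 has its own four-membered ring group (a group of 6 heavy atoms (4 carbon, 2 nitrogen; one four-membered non-aromatic ring with 1 hetero atom) in place of a group of 6 heavy atoms (4 carbon, 2 nitrogen; one four-membered non-aromatic ring with 1 hetero atom), on an aromatic carbon). The two compounds have the same atoms, joined differently. Going by the values given here, no measured pair differs in one place only, so no measured step guides this change. The expected move, a 1.7-fold lower number from compound 1 to compound 3 (0.23 log units; within the scatter), is small and downward, not beyond the scatter. Compound 3 is estimated at 12 ug/mL, with an expected range of 3 ug/mL to 50 ug/mL.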

Compound 3, solubility: 13.9 ug/mL
The estimate for compound 3 lay 1.2-fold (0.06 log units) below the measured number, within the range that was stated.
By their numbers in this assay, from the lowest: compound 2; then compounds 3 and 1 (each within the scatter of the next).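

In this assay, exchanging the group with defined stereocentres for 3-amino-3-methylazetidin-1-yl on this aromatic carbon, ortho to the fluoro group, gives a 1.5-fold lower number from compound 1 to compound 3 (0.16 log units; within the scatter). On the shared core, this rearrangement of the same atoms therefore cannot be told apart from the scatter, and the defined stereocentres are not needed to keep the reading within it. Nothing available explains the result.

On these data alone, what remains open is how this assay responds at this carbon to a larger amine such as piperazine or pyrrolidine. Whether an aminomethyl chain on the azetidine would stay within the scatter is also unresolved.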